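The compounds below may be only part of what the source reports. "The series", "measured", "known", "first", "only" and "open" are said of these compounds alone.

Compound 1 `Cc1ccc(-c2cc(/C=C/c3ccc(C(=O)NO)cc3)ccn2)cc1` gives 150 nM in an assay on isolated protein for inhibition of protein deacetylase HDAC6 (Homo sapiens), read by fluorescence, with a stated time of 15 min; a lower number here means a stronger inhibitor, a higher number a weaker inhibitor. Compound 2 `COc1ccc(-c2cc(/C=C/c3ccc(C(=O)NO)cc3)ccn2)cc1` gives 110 nM in this assay; the step of a 1.4-fold lower number from compound 1 to compound 2 (0.13 log units; within the scatter) leaves the pair within the scatter, so compound 2 stands level with compound 1 and no third number is present. Compound 3 `O=C(NO)c1ccc(/C=C/c2ccncc2)cc1` differs from compound 2 by hydrogen in place of 4-methoxyphenyl on an aromatic carbon. Among the measured compounds shown here, no measured step removes this ring; the single step available only swaps one substituent on it, so it gives no guide to the size of the change. Removal of the whole ring is expected to weaken inhibition beyond the scatter: for compound 3 a value of 600 nM (range 150 nM to 2500 nM) is estimated, a step of a 5.5-fold higher number from compound 2 to compound 3 (0.74 log units; beyond the scatter) being expected.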

Compound 3, half-maximal inhibitory concentration: 130 nM
For compound 3 the middle estimate is 4.6-fold (0.66 log units) above the measured one, and the stated range ends above it.
By their numbers in this assay, from the lowest: compounds 2, 3 and 1 (each within the scatter of the next).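

In this assay, hydrogen in place of 4-methoxyphenyl gives a 1.2-fold higher number from compound 2 to compound 3 (0.07 log units; within the scatter), and hydrogen in place of 4-methylphenyl gives a 1.2-fold lower number from compound 1 to compound 3 (0.06 log units; within the scatter). The aromatic carbon next to the ring nitrogen therefore tolerates loss of the whole aryl ring in this series with no change beyond the scatter, which the methyl-to-methoxy swap could not show while the ring stayed in place. From the compounds shown here alone, whether an amine, a carboxylic acid or a longer chain on this carbon would move the number beyond the scatter stays open. No measurement at hand explains why removing the ring leaves the number level.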